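This account rests on a few compounds, and the source may have more. Where it says the series, first, only, none or still open, it means among the compounds named here.

Measured so far:
compound 1, `CC(C)c1nc2ccc(NC(=O)NCc3ccncc3)cn2n1` — in an assay on isolated protein for activation of Nicotinamide phosphoribosyltransferase (Homo sapiens), read by fluorescence (on this read-out lower numbers stand for an effect already at smaller amounts and higher numbers for an effect only at larger amounts of compound), compound 1 gives 5800 nM
compound 2, `O=C(NCc1cn[nH]c1)Nc1ccc2nc(-c3ccccc3)nn2c1` — in this assay compound 2 gives 22 nM

Compound 2 holds the lower of the two numbers, and its gap to compound 1 is beyond the scatter. Going by the values given here, the two compounds differ at more than one place, so no single step between them can be read.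

Compound 3, `O=C(NCc1cnco1)Nc1ccc2nc(-c3ccccc3)nn2c1`, is not yet measured. It keeps the whole of compound 2 except for one change: 1,3-oxazol-5-yl in place of 1H-pyrazol-4-yl on a saturated chain carbon bound to an amide-type nitrogen. A hydrogen-bond donor is lost and an acceptor gained in the same place, while size stays the same. With no measured step of this kind in the series, the expectation can rest only on the value of compound 2 in this assay and on the nature of the change. A modest weakening is expected, so that the step of a 3.6-fold higher number from compound 2 to compound 3 (0.56 log units; beyond the scatter) goes upward but not far beyond the scatter. Compound 3 is estimated at 80 nM in this assay, within a range of 20 nM to 400 nM.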

Compound 3, half-maximal effective concentration: 140 nM
Estimate against measurement, compound 3: 1.8-fold (0.24 log units) below, within the range that was stated.
By their numbers in this assay, from the lowest: compound 2; then compound 3; then compound 1.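

In this assay, the series now has its first readable single change: 1,3-oxazol-5-yl in place of 1H-pyrazol-4-yl gives a 6.4-fold higher number from compound 2 to compound 3 (0.80 log units; beyond the scatter) on a saturated chain carbon bound to an amide-type nitrogen. This place therefore responds to the exchange of one five-membered aromatic ring for another, although both groups have 5 heavy atoms and 2 hetero atoms in the ring. The change also takes the group from 1 hydrogen-bond donor to 0 and from 1 acceptor to 2, but no measurement available here ties the step to either count.

From the compounds shown here alone, whether a 1H-imidazol-4-yl group or a plain phenyl ring would fit this place as well as 1H-pyrazol-4-yl remains open. Also open, going by these compounds, are the effect of a longer chain to the ring and whether the same exchange would give a similar step on the core of compound 1.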